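The source may hold more compounds than are shown below. What is called first, only, known or untested is meant among the compounds shown, and "the series" means these compounds.

Measured compounds: compound 1 `C[C@@H](O)[C@H](NC(=O)CN(c1nc(Cl)nc2[nH]cnc12)C1CC1)C(=O)O` with 37.6%; compound 2 `CSCC[C@H](NC(=O)CN(c1nc(Cl)nc2[nH]cnc12)C1CC1)C(=O)O` with 5.67%; compound 3 `NC(=O)C[C@H](NC(=O)CN(c1nc(Cl)nc2[nH]cnc12)C1CC1)C(=O)OCc1ccccc1` with 15.1%, all in a functional assay on the whole organism (Tail, strain ICR) with Mus musculus as the target, in the tail flick test, with a stated time of 120 min, at a dose of 25 umol/kg by the oral route; a lower number here means a weaker effect, a higher number a stronger effect of the compound at the dose given.

Compound 3 sits between the other two values: its gap to compound 2 lies within the scatter, while compound 1 stands beyond the scatter above it. Compound 4 `NC(=O)C[C@H](NC(=O)CN(c1nc(Cl)nc2[nH]cnc12)C1CC1)C(=O)O` differs from compound 3 by hydrogen in place of benzyl on an oxygen next to a carbonyl group. Going by the values given here, the only measured step, a number 31.9 percentage points lower from compound 1 to compound 2 (beyond the scatter), concerns a change on the saturated chain carbon, not the oxygen next to the carbonyl group, so no measured step bears directly on this change. Compounds 1 and 2 both carry the carboxy group that compound 4 gains, and their values span a wide interval. The expected step is therefore a number 4.9 percentage points higher from compound 3 to compound 4 (within the scatter), essentially none beyond the scatter, and compound 4 is estimated at 20%, between 4% and 40%.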

Compound 4, a percentage reported as activity, at one dose (the size of the read-out at that dose, not a potency): 17%
For compound 4 the middle estimate is 3 percentage points above the measured one, within the range that was stated.
By their numbers in this assay, from the lowest: compounds 2, 3 and 4 (each within the scatter of the next, the first and the last beyond it); then compound 1.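

In this assay, hydrogen in place of benzyl on an oxygen next to a carbonyl group gives a number 1.9 percentage points higher from compound 3 to compound 4 (within the scatter), so this read-out does not separate benzyloxycarbonyl from carboxy at this place. With carboxy held, the saturated chain carbon still counts: carbamoyl in place of (methylsulfanyl)methyl gives a number 11.3 percentage points higher from compound 2 to compound 4 (beyond the scatter) and carbamoylmethyl in place of 1-hydroxyethyl gives a number 20.6 percentage points lower from compound 1 to compound 4 (beyond the scatter). Nothing available accounts for these results. Open, on these data alone, is whether an ethyl group on that oxygen would read like benzyl and hydrogen, and whether benzyl there would leave compound 1 equally unmoved.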